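The compounds below may be only part of what the source reports. "The series", "measured", "known", "first", "only" and "open" are said of these compounds alone.

Compound 3 `CC1(C)C=C(n2ccccc2=O)c2cc(S(=O)(=O)N3CCOCC3)ccc2O1` carries a morpholin-4-yl group on its sulfonyl sulfur. For the measured compounds named here, in a functional assay on the whole organism (trachea) with Rattus norvegicus as the target (on this read-out higher numbers stand for larger maximal responses and lower numbers for smaller maximal responses), compound 3 gives 85.1%, the second highest of the three numbers measured so far. Its two neighbours differ from it only at the sulfonyl group: compound 1 `CNS(=O)(=O)c1ccc2c(c1)C(n1ccccc1=O)=CC(C)(C)O2` gives 83% and compound 2 `CC1(C)C=C(n2ccccc2=O)c2cc(S(=O)(=O)NCCO)ccc2O1` gives 87.9%. The measured steps are all small: a number 4.9 percentage points higher from compound 1 to compound 2 (within the scatter), a number 2.1 percentage points higher from compound 1 to compound 3 (within the scatter) and a number 2.8 percentage points lower from compound 2 to compound 3 (within the scatter). Each lies within the scatter, so the three compounds cannot be ranked against one another.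

Compound 4 `CC1(C)C=C(n2ccccc2=O)c2cc(S(=O)(=O)c3ccccc3)ccc2O1` takes the same position one step further: phenyl in place of morpholin-4-yl on a sulfonyl sulfur. The two steps that bear on it, a number 2.1 percentage points higher from compound 1 to compound 3 (within the scatter) and a number 2.8 percentage points lower from compound 2 to compound 3 (within the scatter), both exchanged the group on the sulfonyl sulfur without moving the read-out beyond the scatter. Neither of them, however, replaced a nitrogen-linked group by a carbon-only aromatic ring, so the comparison is indirect. On that evidence the expected step is a number 1.1 percentage points lower from compound 3 to compound 4 (within the scatter), which is no change beyond the scatter. Compound 4 is therefore expected to reach 84%, within a range from 70% to 96%.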

Compound 4, largest response reached (Emax), in percent of the reference or control that the assay uses: 88.1%
Beside the measured number, compound 4's estimate is 4.1 percentage points below it; the measured number falls inside the stated range.
By their numbers in this assay, from the lowest: compounds 1, 3, 2 and 4 (each within the scatter of the next).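

Compound 4 shows that the group on the sulfonyl sulfur need not be attached through nitrogen. In this assay, replacing the nitrogen-linked groups with phenyl, a six-membered aromatic ring of carbon only, gives a number 3 percentage points higher from compound 3 to compound 4 (within the scatter), a number 0.2 percentage points higher from compound 2 to compound 4 (within the scatter) and a number 5.1 percentage points higher from compound 1 to compound 4 (within the scatter), so even a group with no hydrogen-bond donors or acceptors leaves all four compounds unranked. No measurement here explains why the maximal response stays within the scatter across these different groups.

On these data alone, it remains open whether a methyl, a piperazin-1-yl or a chain ending in a carboxylic acid on the sulfonyl sulfur would also stay within the scatter. Also open, as far as these compounds go, is what would happen if a nitrile replaced the whole sulfonyl group, or if the phenyl ring carried a fluorine or methoxy group.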